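The source may report more compounds than this note shows. Statements on the series, on what has been measured and on what is new or still open speak of the compounds shown alone.

Measured so far:
compound 1 `O=C(Nc1cccc(Nc2ncc(F)c(Nc3ccc(F)cc3)n2)c1)c1cnccn1`, 23600 nM
compound 2 `CN1CCC(C(=O)Nc2cccc(Nc3ncc(F)c(Nc4ccc(F)cc4)n3)c2)CC1`, 1700 nM
compound 3 `O=C(Nc1cccc(Nc2ncc(F)c(Nc3ccc(F)cc3)n2)c1)c1ccccc1`, a limit of the assay, > 10000 nM

In a functional assay on KB cells (Homo sapiens) for antiproliferative activity, read by sulforhodamine B assay, with a stated time of 3 days (on this read-out higher numbers stand for weaker inhibition of growth and lower numbers for stronger inhibition of growth), compound 1 stands highest of the two numbers given; the nearest is a 14-fold lower number from compound 1 to compound 2 (1.14 log units; beyond the scatter). Compound 3 gives only a limit in this assay (the limit of > 10000 nM in this assay, at which 1 of the 3 values shown sits). The step of an at least 5.8-fold higher number from compound 2 to compound 3 (0.76 log units; beyond the scatter) shows the aryl amide falling behind the saturated amine amide.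

Compound 4 `O=C(NCCO)c1cccc(Nc2ncc(F)c(Nc3ccc(F)cc3)n2)c1` differs from compound 1 by (2-hydroxyethyl)carbamoyl in place of ((pyrazin-2-yl)carbonyl)amino on an aromatic carbon. Among the measured compounds shown here, no measured step reverses the amide or introduces a hydroxyethyl chain, so the steps on record bear on it only loosely: the one clear gain, a 14-fold lower number from compound 1 to compound 2 (1.14 log units; beyond the scatter), came from a different group on the same side chain. A small step in this assay, likely within the scatter or slightly toward a lower number, is expected: a 2.6-fold lower number from compound 1 to compound 4 (0.42 log units; beyond the scatter). Compound 4 is therefore estimated at 9000 nM (range 2500 nM to 30000 nM).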

Compound 4, concentration for 50% growth inhibition: 12400 nM
Beside the measured number, compound 4's estimate is 1.4-fold (0.14 log units) below it, and the stated range covers the measured number.
By their numbers in this assay, from the lowest: compound 2; then compounds 4 and 1 (each within the scatter of the next).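

In this assay, exchanging ((pyrazin-2-yl)carbonyl)amino for (2-hydroxyethyl)carbamoyl on this aromatic carbon, with its reversed amide and no ring, gives no readable change, with a 1.9-fold lower number from compound 1 to compound 4 (0.28 log units; within the scatter). The ((1-methylpiperidin-4-yl)carbonyl)amino group keeps its lead over the new side chain, with a 7.3-fold higher number from compound 2 to compound 4 (0.86 log units; beyond the scatter). The step involving compound 3 cannot be read, as its value is a limit of the assay: the limit of > 10000 nM in this assay, at which 1 of the 4 values shown sits.

As far as these compounds go, whether that lead depends on the amide direction remains open. A reversed amide ending in a dimethylamino group or a carboxylic acid, or carrying a longer chain, would test this.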